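A few compounds are considered here, and "the series" means these few. Any claim that something is new, unique, unknown or untested is made for them only; others in the source may bear on it.

Compound 1 `COc1ccc(-c2c(C)nc(S)n2Nc2cccc(Cl)c2)cc1`: 38700 nM
Compound 2 `Cc1nc(S)n(Nc2cccc(Cl)c2)c1-c1cccc(Cl)c1`: 31000 nM
Compound 3 `CC1N=C(S)N(Nc2ccccc2)C1C`: 181000 nM

In a functional assay on MT4 cells (Homo sapiens) for cytotoxicity (on this read-out higher numbers stand for lower toxicity in this test and lower numbers for higher toxicity in this test), compound 2 has the lowest of the three numbers. Its nearest neighbour is compound 1, whose number lies within the scatter of that of compound 2; compound 3 stands furthest off, beyond the scatter. Compound 4 `Cc1nc(S)n(Nc2cccc(Cl)c2)c1-c1cccc(Br)c1` is not yet measured in this assay. It differs from compound 2 in one place: bromo in place of chloro on an aromatic carbon. Going by the values given here, no measured pair shows this same change, so no step can be drawn on. The exchange of chloro for bromo is expected to leave the number roughly where compound 2 stands, with no step beyond the scatter in either direction. The expected step is a 1.1-fold lower number from compound 2 to compound 4 (0.04 log units; within the scatter). Compound 4 is accordingly estimated at 28000 nM, within a range from 12000 nM to 70000 nM.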

Compound 4, half-maximal cytotoxic concentration: 44000 nM
Compound 4: the middle estimate sits 1.6-fold (0.20 log units) below what was measured; measured number inside the range.
By their numbers in this assay, from the lowest: compounds 2, 1 and 4 (each within the scatter of the next); then compound 3.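

In this assay, the exchange of 3-chlorophenyl for 3-bromophenyl gives a 1.4-fold higher number from compound 2 to compound 4 (0.15 log units; within the scatter), the only step shown between compounds that differ in one place. At this position, on the six-membered aromatic ring of carbon only, bromo can therefore take the place of chloro without a step beyond the scatter. No evidence is available that would explain this result.

On these data alone, it remains open whether a different kind of group here, such as an amine or a carboxylic acid, would also stay within the scatter of compound 2. As far as these compounds go, it is equally open whether bromo in place of the other chloro of compound 2 would behave alike.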